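This account rests on a few compounds, and the source may have more. Where it says the series, first, only, none or still open, it means among the compounds named here.

Three compounds share one core. Compound 1, `O=S(=O)(NCCCNc1nccc(-c2c(-c3cccc(F)c3)nc3sccn23)n1)c1ccc(Br)cc1`, gives 7040 nM in a functional assay on A-375 cells (Homo sapiens) for cytotoxicity, read by MTT assay; a higher number here means a weaker inhibitor, a lower number a stronger inhibitor. Compound 2, `O=C(NCCNc1nccc(-c2c(-c3cccc(F)c3)nc3sccn23)n1)c1ccc(Cl)cc1`, gives 2570 nM in this assay. Compound 3, `O=S(=O)(NCCNc1nccc(-c2c(-c3cccc(F)c3)nc3sccn23)n1)c1ccc(F)cc1`, gives 9450 nM in this assay. Against compound 2 the step is a 3.7-fold higher number from compound 2 to compound 3 (0.57 log units; beyond the scatter), so compound 3 sits clearly apart from it, whereas the step of a 1.3-fold higher number from compound 1 to compound 3 (0.13 log units; within the scatter) leaves compound 1 and compound 3 within the scatter of each other.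

Compound 4, `O=S(=O)(NCCNc1nccc(-c2c(-c3cccc(F)c3)nc3sccn23)n1)c1ccc(Br)cc1`, differs from compound 3 by bromo in place of fluoro on an aromatic carbon. Among the compounds with values here, no measured pair isolates this exchange alone: the step of a 1.3-fold higher number from compound 1 to compound 3 (0.13 log units; within the scatter) carries the same bromo-to-fluoro exchange but together with a change in chain length, and it stayed within the scatter. Within the data shown here, that is the only step bearing on the case, so for this assay no shift beyond the scatter is expected in either direction.

Compound 4 is therefore estimated at 8000 nM, with a range from 4000 nM to 16000 nM. The expected step of a 1.2-fold lower number from compound 3 to compound 4 (0.07 log units; within the scatter) is thus held to lie within the scatter.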

Compound 4, half-maximal inhibitory concentration: 13500 nM
Estimate against measurement, compound 4: 1.7-fold (0.23 log units) below; the measured number falls inside the stated range.
By their numbers in this assay, from the lowest: compound 2; then compounds 1, 3 and 4 (each within the scatter of the next).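

With the exchange now seen alone in this assay, bromo in place of fluoro on the aromatic carbon para to a large group gives a 1.4-fold higher number from compound 3 to compound 4 (0.15 log units; within the scatter) and so does not separate these two sulfonyl compounds. With the 4-bromophenyl group held fixed, the chain change alone gives a 1.9-fold higher number from compound 1 to compound 4 (0.28 log units; within the scatter) and also stays within the scatter, which the earlier step from compound 1 to compound 3 could not show because it carried both changes at once. The gap to the carbonyl compound now appears with a second halogen, as a 5.3-fold higher number from compound 2 to compound 4 (0.72 log units; beyond the scatter) lies beyond the scatter.

That step changes both the link and the halogen. A 4-bromobenzoyl or 4-fluorobenzoyl group on the same chain would be needed to tell which of the two carries the gap, and a methoxy or an unsubstituted phenyl ring remains untested among the compounds shown. No evidence here gives a reason for any of these steps.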